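The source may report more compounds than this note shows. Statements on the series, on what has been measured and on what is new or still open speak of the compounds shown alone.

Compound 1 `COc1ccc2c(/C=C/C(=O)c3cc(OC)c(OC)c(SC)c3)c[nH]c2c1` is measured in a functional assay on A549 cells (Homo sapiens) for antiproliferative activity, read by MTT assay, with a stated time of 48 h (on this read-out lower numbers stand for stronger inhibition and higher numbers for weaker inhibition), where compound 1 gives 115 nM. Among the three numbers shown, compound 1 stands second highest. Its nearest neighbour is compound 3 `COc1ccc2c(/C=C/C(=O)c3cc(OC)c(OC)c(SC)c3)cn(C)c2c1`, which in this assay gives 156 nM; the step of a 1.4-fold higher number from compound 1 to compound 3 (0.13 log units; within the scatter) is a methyl in place of hydrogen on an aromatic nitrogen. Further off lies compound 2 `COc1ccc2c(/C=C/C(=O)c3cc(OC)c(OC)c([Se]C)c3)c[nH]c2c1`, which gives 67 nM; the step of a 1.7-fold lower number from compound 1 to compound 2 (0.23 log units; within the scatter) exchanges the group of carbon and sulfur for one of carbon and selenium on an aromatic carbon.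

Compound 4 `COc1cc(C(=O)/C=C/c2c[nH]c3ccccc23)cc(SC)c1OC` differs from compound 1 by hydrogen in place of methoxy on an aromatic carbon, on a six-membered aromatic ring of carbon only that is part of a fused system of two rings. Neither measured step touches that ring, so none bears directly on this change; both are within the scatter, which suggests the shared core tolerates small changes without large shifts. In this assay the step of a 1.3-fold higher number from compound 1 to compound 4 (0.12 log units; within the scatter) is therefore expected to stay within the scatter. Compound 4 is estimated at 150 nM, with a range from 60 nM to 400 nM.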

Compound 4, half-maximal inhibitory concentration: 152 nM
Estimate against measurement, compound 4: 1.0-fold (0.01 log units) below; measured number inside the range.
By their numbers in this assay, from the lowest: compounds 2, 1, 4 and 3 (each within the scatter of the next, the first and the last beyond it).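

Compound 4 is the first compound shown that changes the fused ring system itself, since the earlier steps touched only the group of carbon and sulfur and the aromatic nitrogen. In this assay the result is a 1.3-fold higher number from compound 1 to compound 4 (0.12 log units; within the scatter) and so stays within the scatter: with hydrogen in place of methoxy on this aromatic carbon, the number cannot be told apart from that of compound 1, so activity at this level does not depend on the methoxy. No measurement shown here explains this result.

From the compounds shown here alone, it remains open whether another group at this place, such as an amine, a hydroxyl or a longer alkoxy chain, would give a number beyond the scatter. Going by these compounds, it is also open whether hydrogen in place of methoxy would read the same alongside the selenium-containing group of compound 2 or the nitrogen methyl of compound 3.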